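The compounds below may be only part of what the source reports. "The series", "measured", "known", "first", "only" and "open" are said of these compounds alone.

The compounds measured so far in a functional assay on KB cells (Homo sapiens) for cytotoxicity, read by sulforhodamine B assay; a higher number here means a weaker inhibitor, a lower number a stronger inhibitor:

Compound 1 `C=C1[C@@H](OC(C)=O)C[C@@H]2[C@](C)(COC=O)[C@H](OC(C)=O)CC[C@@]2(C)[C@@H]1C[C@@H](Nc1ccccc1C(=O)O)C1=CCOC1=O` gives 42500 nM.
Compound 2 `C=C1[C@@H](OC(C)=O)C[C@@H]2[C@](C)(COC=O)[C@H](OC(C)=O)CC[C@@]2(C)[C@@H]1C[C@@H](Nc1ccc(OC)c(OC)c1)C1=CCOC1=O` gives only a limit of the assay, > 50000 nM.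
Compound 3 `C=C1[C@@H](OC(C)=O)C[C@@H]2[C@](C)(COC=O)[C@H](OC(C)=O)CC[C@@]2(C)[C@@H]1C[C@@H](Nc1ccc(F)cc1)C1=CCOC1=O` gives 22900 nM.

Compound 1 stands highest of the two numbers; its nearest neighbour is compound 3, with a 1.9-fold lower number from compound 1 to compound 3 (0.27 log units; within the scatter). Compound 2 sits at the limit of > 50000 nM in this assay, at which 1 of the 3 values shown sits. All three differ only in the aryl group on the amine nitrogen.

Compound 4 `C=C1[C@@H](OC(C)=O)C[C@@H]2[C@](C)(CO[Si](C)(C)C(C)(C)C)[C@H](OC(C)=O)CC[C@@]2(C)[C@@H]1C[C@@H](Nc1ccccc1C(=O)O)C1=CCOC1=O` departs from compound 1 elsewhere: a group of 7 heavy atoms (6 carbon, 1 silicon; no ring) in place of a group of 2 heavy atoms (1 carbon, 1 oxygen; no ring), on an oxygen on a saturated carbon. Within the data shown here, no measured step touches this oxygen, so no comparison bears on the change directly. Compound 4 is therefore expected to show a 1.1-fold lower number from compound 1 to compound 4 (0.03 log units; within the scatter), with no step beyond the scatter. Compound 4 is estimated at 40000 nM, between 15000 nM and 100000 nM.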

Compound 4, half-maximal inhibitory concentration: 6050 nM
The estimate for compound 4 lay 6.6-fold (0.82 log units) above the measured number; the measured number lies below the stated range.
By their numbers in this assay, from the lowest: compound 4; then compounds 3 and 1 (each within the scatter of the next). At a limit, above all of these: compound 2.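

In this assay, the group of 7 heavy atoms (6 carbon, 1 silicon) in place of formyl gives a 7.0-fold lower number from compound 1 to compound 4 (0.85 log units; beyond the scatter), a step beyond the scatter. Among these compounds, this shows that the number also responds to a change on an oxygen on a saturated carbon, a place the earlier compounds left untouched, and not only to the aryl group on the amine nitrogen. No measurement shown accounts for this step. The compounds shown leave open how a free hydroxyl, an acetyl or a benzyl group on this oxygen would compare. They also leave open whether the same change would carry over to the 4-fluorophenyl group of compound 3.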